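The source may report more compounds than this note shows. Statements on the series, on what has been measured and on what is new or still open speak of the compounds shown alone.

In an assay on membranes from HeLa cells for displacement of a labelled ligand from adenosine receptor A3 (Homo sapiens), read by scintillation counting, with a stated time of 180 min, tested at 1 uM (on this read-out higher numbers stand for more inhibition at the one concentration tested (going by the name of the read-out) and lower numbers for less inhibition), compound 1 `CCCOC(=O)C1=C(C)NC(=S)NC1c1ccco1` gives 1%. Compound 2 `CC1=C(C(=O)OCC(C)C)C(c2ccco2)NC(=S)N1` differs from compound 1 by methyl in place of hydrogen on a saturated chain carbon bound to two saturated chain carbons and, in this assay, compound 2 gives 10%, a step of a number 9 percentage points higher from compound 1 to compound 2 (within the scatter). Compound 3 `CCCOC(=O)C1=C(C)NC(=S)NC1c1ccoc1` carries a changed core relative to compound 1, the difference being (furan-3-yl in place of furan-2-yl on a saturated ring carbon); in this assay compound 3 gives 3%, a step of a number 2 percentage points higher from compound 1 to compound 3 (within the scatter).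

Compound 4 `CC1=C(C(=O)OCC(C)C)C(c2ccoc2)NC(=S)N1` has not yet been measured in this assay. It differs from compound 3 by methyl in place of hydrogen on a saturated chain carbon bound to two saturated chain carbons, which is the same change as that from compound 1 to compound 2, set at the same place; among these four compounds the change occurs twice in all. Given that the earlier instance of this change produced only a number 9 percentage points higher from compound 1 to compound 2 (within the scatter), and that compound 3 starts from 3%, compound 4 is expected to shift by a number 8 percentage points higher from compound 3 to compound 4 (within the scatter) in this assay. On that basis compound 4 is estimated at 11% in this assay, with a likely range from 0% to 25%.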

Compound 4, a percentage reported as inhibition, at one concentration (the size of the read-out at that concentration, not a potency): 1%
The estimate for compound 4 lay 10 percentage points above the measured number, within the range that was stated.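

In this assay, the change from propoxy to isobutoxy now gives a number 2 percentage points lower from compound 3 to compound 4 (within the scatter), and its two instances do not differ beyond the scatter: the same change on two cores in this assay, a number 9 percentage points higher (within the scatter) from compound 1 to compound 2 and a number 2 percentage points lower (within the scatter) from compound 3 to compound 4, 11 percentage points apart, within the scatter of two such steps

The furan-3-yl in place of furan-2-yl gives a number 9 percentage points lower from compound 2 to compound 4 (within the scatter), and its two instances likewise agree within the scatter: the same change on two cores in this assay, a number 2 percentage points higher (within the scatter) from compound 1 to compound 3 and a number 9 percentage points lower (within the scatter) from compound 2 to compound 4, 11 percentage points apart, within the scatter of two such steps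

Going by these compounds alone, this agreement does not show that an effect carries from one core to another, since every step here lies within the scatter and there is no measurable effect to carry; it shows only that neither change produced a step that can be told from the scatter at the one concentration tested.

The compounds shown leave open whether any change to this series can give a step beyond the scatter in this assay. A longer chain on the ester, a carboxylic acid in place of the ester, or a phenyl ring in place of the furan might answer that, and the four compounds give no indication either way.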